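A few compounds are considered here, and "the series" means these few. Any claim that something is new, unique, unknown or untested is made for them only; others in the source may bear on it.

Of the compounds shown here, two have so far been tested in an ADME assay on NIH3T3 cells (Mus musculus) for cytotoxicity, read by CCK-8 assay, with a stated time of 24 h; a lower number here means a stronger inhibitor, a higher number a weaker inhibitor. Compound 1 (`C=C1CCC(c2csc(/C=C(\C)C(N)=O)c2)CC1`) gives > 50000 nM, which is a limit of the assay rather than a number. Compound 2 (`C/C(=C\c1cc(-c2cccnc2)co1)C(N)=O`) likewise gives > 50000 nM, again a limit of the assay and not a number. Among the measured compounds shown here, compound 2 therefore stands at the limit of > 50000 nM in this assay, at which 2 of the 2 values shown sit, the same place as the only other measured compound. Compound 3 (`C/C(=C\c1cc(-c2ccc(C)nc2)co1)C(N)=O`) differs from compound 2 by one change: methyl in place of hydrogen on an aromatic carbon. For the measured compounds named here, no measured pair shows what such a change does in this assay. With both measured compounds resting at the limit, the expected step that the limit leaves unreadable from compound 2 to compound 3 is none beyond the usual scatter. Compound 3 is accordingly estimated at 80000 nM, within a range from 40000 nM to 200000 nM, most likely reported once more as a limit.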

Compound 3, half-maximal inhibitory concentration: > 50000 nM
Compound 3 ended at the assay's limit; the forecaster's own chance of this, stated with the estimate: 85%; the middle value does not contradict the limit.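

Compound 2 and compound 3 both rest at the limit of the assay rather than at a number, so no step can be read between them. The compounds shown leave open what methyl in place of hydrogen on an aromatic carbon does in this assay.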